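The source may hold more compounds than are shown below. What is called first, only, known or untested is meant among the compounds shown, and "the series" means these compounds.

Series notes. Compound 1 `COC(=O)c1ccc(NC2=CC(=O)c3ncncc3C2=O)cc1` carries a methoxycarbonyl on an aromatic carbon of the shared core's pendant ring; in a functional assay on BXPC-3 cells (Homo sapiens) for cytotoxicity, read by MTT assay, with a stated time of 72 h (on this read-out higher numbers stand for weaker inhibition and lower numbers for stronger inhibition), compound 1 gives 5800 nM. Compound 2 `Nc1ccc(-c2ccc(NC3=CC(=O)c4ncncc4C3=O)cc2)cc1`, with a 4-aminophenyl in that place, gives 3500 nM in this assay, and compound 3 `O=C1C(Nc2ccc(-c3ccc(F)cc3)cc2)=CC(=O)c2ncncc21`, with a 4-fluorophenyl there, gives 4400 nM. The three steps that connect them, a 1.7-fold lower number from compound 1 to compound 2 (0.22 log units; within the scatter), a 1.3-fold lower number from compound 1 to compound 3 (0.12 log units; within the scatter) and a 1.3-fold higher number from compound 2 to compound 3 (0.10 log units; within the scatter), all stay within the scatter, so compound 3 stands inside the spread of the other two rather than apart from it, its nearest neighbour being compound 2 and its furthest compound 1, both within the scatter.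

The next compound, compound 4 `O=C1C(Nc2ccc(Oc3ccccc3)cc2)=CC(=O)c2ncncc21`, differs from compound 3 by phenoxy in place of 4-fluorophenyl on an aromatic carbon. Among the compounds with values here, the three measured steps concern the same aromatic carbon and cover three different groups there without any step beyond the scatter; none of them involves a phenoxy, so no direct precedent for this group exists. On that basis a step of no change at the digits printed from compound 3 to compound 4 (within the scatter) is expected, which means none beyond the scatter. Compound 4 is therefore estimated at 4400 nM in this assay, with a range from 1500 nM to 13000 nM.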

Compound 4, half-maximal inhibitory concentration: 3600 nM
Estimate against measurement, compound 4: 1.2-fold (0.09 log units) above, within the range that was stated.
By their numbers in this assay, from the lowest: compounds 2, 4, 3 and 1 (each within the scatter of the next).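

Phenoxy in place of 4-fluorophenyl gives a 1.2-fold lower number from compound 3 to compound 4 (0.09 log units; within the scatter) in this assay, so attaching the aromatic ring through an oxygen, a linkage absent from the earlier compounds, and bringing in a hydrogen-bond acceptor does not separate compound 4 from compound 3. Within the data shown here, the comparisons with the other two groups read the same way, with a 1.0-fold higher number from compound 2 to compound 4 (0.01 log units; within the scatter) and a 1.6-fold lower number from compound 1 to compound 4 (0.21 log units; within the scatter), which extends the flat picture at this aromatic carbon to four groups, with no compound among the four going against it. No accompanying data bear on why these groups are not told apart by this read-out.

From the compounds shown here alone, it remains open whether a group of a different kind at this carbon, such as a carboxylic acid, a morpholine or a longer alkyl chain, would give a step beyond the scatter, or whether this position simply has little bearing on the read-out. Going by these compounds, all four values also come from a single cell line, so it is equally open whether the same flat picture would hold in other cells.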